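Iodomethyl analogue in the enone sulfone series: expected in vivo inhibition

The compounds below may be only part of what the source reports. "The series", "measured", "known", "first", "only" and "open" are said of these compounds alone.

Compound 1 `O=C1C=CS(=O)(=O)c2ccccc21`: 5.5%
Compound 2 `CC(=O)OCC1=CS(=O)(=O)c2ccccc2C1=O`: 99.5%
Compound 3 `O=C1C(CNc2ccccc2)=CS(=O)(=O)c2ccccc21`: 0%

In a functional assay on the whole organism for inhibition, with Mus musculus as the target, at a dose of 10 mg/kg (on this read-out higher numbers stand for more inhibition at the one dose given (going by the name of the read-out) and lower numbers for less inhibition), compound 3 gives the lowest of the three numbers; its gap to compound 1 lies within the scatter, while compound 2 stands far higher. For the measured compounds named here, the only substituted analogues are compound 2 and compound 3, and the two measured steps are large: a number 94 percentage points higher from compound 1 to compound 2 (beyond the scatter) and a number 99.5 percentage points lower from compound 2 to compound 3 (beyond the scatter). So the number in this assay is much higher or much lower depending on what sits on the saturated chain carbon bound to a double-bonded ring carbon.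

Compound 4 `O=C1C(CI)=CS(=O)(=O)c2ccccc21` differs from compound 3 as follows: iodo in place of anilino on a saturated chain carbon bound to a double-bonded ring carbon. The step that bears on it most directly is a number 99.5 percentage points lower from compound 2 to compound 3 (beyond the scatter), which shows that exchanging the group on that chain carbon can move the number across the full range. Going by the values given here, no step from anilino to iodo has been measured, so the direction must be taken from the fact that compound 2 reached 99.5% with a one-atom-linked substituent at this place while compound 3 with anilino gave 0%. A large upward step, a number 70 percentage points higher from compound 3 to compound 4 (beyond the scatter), is therefore expected, though with wide uncertainty. Compound 4 is estimated at 70% in this assay, within a range from 15% to 100%.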

Compound 4, a percentage reported as inhibition, in the whole organism at one dose (the size of the read-out at that dose, not a potency): 98%
Compound 4: middle estimate off by 28 percentage points, on the low side; measured number inside the range.
By their numbers in this assay, from the lowest: compounds 3 and 1 (each within the scatter of the next); then compounds 4 and 2 (each within the scatter of the next).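

In this assay iodo in place of anilino on a saturated chain carbon bound to a double-bonded ring carbon gives a number 98 percentage points higher from compound 3 to compound 4 (beyond the scatter) and so the low number goes with anilino, not with every group at this place. Iodo in place of acetoxy gives a number 1.5 percentage points lower from compound 2 to compound 4 (within the scatter) and so the high number does not depend on acetoxy alone. Iodomethyl in place of hydrogen on a double-bonded ring carbon gives a number 92.5 percentage points higher from compound 1 to compound 4 (beyond the scatter) and so compound 2 is no longer the only compound to stand clear of the unsubstituted core.

Going by these compounds, whether a chloro, a hydroxy or a dimethylamino group on the same chain carbon would follow iodo or anilino stays open. No evidence in hand bears on what separates these groups in the whole organism.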